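A few compounds are considered here, and "the series" means these few. Any claim that something is new, unique, unknown or untested is made for them only; others in the source may bear on it.

Working notes on the series. In a functional assay on MT4 cells (Homo sapiens) for antiproliferative activity, read by MTT assay, with a stated time of 96 h (on this read-out lower numbers stand for an effect already at smaller amounts and higher numbers for an effect only at larger amounts of compound), compound 1 `N#C/C(=C\c1c(-c2ccccc2)[nH]c2ccccc12)C(=O)c1ccccc1` gives 500 nM. Compound 2 `N#C/C(=C\c1c[nH]c2ccccc12)S(=O)(=O)c1ccccc1` reaches only > 100000 nM, which is a limit of the assay and not a number. Among the compounds with values here, compound 3 `COc1ccc2[nH]c(-c3ccccc3)c(/C=C(\C#N)S(=O)(=O)c3ccccc3)c2c1` gives 1300 nM, the highest of the two numbers measured so far; compound 1 sits lower by a step beyond the usual scatter. Compound 4 `N#C/C(=C\c1c(-c2ccccc2)[nH]c2ccccc12)S(=O)(=O)c1ccccc1` is not yet measured in this assay. It differs from compound 3 in one place: hydrogen in place of methoxy on an aromatic carbon. Within the data shown here, no step between measured compounds mirrors this change, so its size is not fixed by the data. The change is expected to move the number little, within the scatter, no change at the digits printed from compound 3 to compound 4 (within the scatter). Compound 4 is therefore estimated at 1300 nM, between 300 nM and 6000 nM.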

Compound 4, half-maximal effective concentration: 400 nM
Beside the measured number, compound 4's estimate is 3.3-fold (0.51 log units) above it; the range from low to high includes it.
By their numbers in this assay, from the lowest: compounds 4 and 1 (each within the scatter of the next); then compound 3. At a limit, above all of these: compound 2.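

In this assay, hydrogen in place of methoxy on this aromatic carbon gives a 3.3-fold lower number from compound 3 to compound 4 (0.51 log units; beyond the scatter) and so the methoxy is not needed for the effect in this pair. Phenylsulfonyl in place of benzoyl gives a 1.3-fold lower number from compound 1 to compound 4 (0.10 log units; within the scatter) and so the two groups are not told apart here. Phenyl in place of hydrogen gives an at least 250-fold lower number from compound 2 to compound 4 (2.39 log units; beyond the scatter) and this largest step rests on a limit of the assay: the limit of > 100000 nM in this assay, at which 1 of the 4 values shown sits.

Going by these compounds, whether an amine or a chlorine at the methoxy position would keep the number stays open. So does the effect of a carboxylic acid on the phenyl group.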